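The compounds below may be only part of what the source reports. "The series", "measured", "known", "first", "only" and "open" are said of these compounds alone.

Measured compounds in a functional assay on HT-29 cells (Homo sapiens) for cytotoxicity, read by MTT assay, with a stated time of 72 h; on this read-out lower numbers stand for stronger inhibition of growth and higher numbers for weaker inhibition of growth:
- compound 1 `COc1ccc(CNc2nc([Se]C)nc3ccccc23)cc1`; in this assay compound 1 gives > 100000 nM, which is a limit of the assay and not a number.
- compound 2 `C[Se]c1nc(NCc2ccccc2)c2ccccc2n1`; in this assay compound 2 gives 81000 nM.

Compound 1 therefore stands only as a limit, its entry sitting at the limit of > 100000 nM in this assay, at which 1 of the 2 values shown sits; no number for it is known. Going by the values given here, the single measured step, an at least 1.2-fold lower number from compound 1 to compound 2 (0.09 log units; that floor lies within the scatter), removes the methoxy at another site and stays within the scatter, so the two values shown lie close to each other with no order between them.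

Compound 3 `COc1ccc(CNc2nc(S)nc3ccccc23)cc1` differs from compound 1 by one sulfur atom in place of a group of 2 heavy atoms (1 carbon, 1 selenium; no ring), on an aromatic carbon. Among the compounds with values here, no measured step in this assay touches that carbon of the shared core; the one step known concerns the methoxy and says nothing about the exchange at the sulfur-bearing position. Within the data shown here, the step from compound 1 to compound 3 thus has no precedent, and the only anchor is the limit of compound 1. Compound 3 is expected to remain near that limit, with a step of a number no higher from compound 1 to compound 3 (the limit leaves the size open) expected to be no larger than the scatter. Compound 3 is estimated at 100000 nM, between 40000 nM and 250000 nM.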

Compound 3, concentration for total growth inhibition: 28600 nM
Beside the measured number, compound 3's estimate is 3.5-fold (0.54 log units) above it, and the stated range ends above it.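

In this assay, exchanging the group of 2 heavy atoms (1 carbon, 1 selenium) for sulfanyl, on the aromatic carbon between two ring nitrogen atoms, gives an at least 3.4-fold lower number from compound 1 to compound 3 (0.54 log units; beyond the scatter). Going by these compounds alone, this is the first sign that this carbon of the shared core affects the read-out, since the only earlier step, an at least 1.2-fold lower number from compound 1 to compound 2 (0.09 log units; that floor lies within the scatter), concerned the methoxy and has a floor that does not clear the scatter. The true size of the new step remains unknown, as the entry for compound 1 is a limit of the assay and not a number: the limit of > 100000 nM in this assay, at which 1 of the 3 values shown sits.

Open, from the compounds shown here alone, is whether the step follows from the sulfur atom itself or from the loss of the carbon, a question a methylsulfanyl group on this aromatic carbon would address, and how an amine or a hydroxyl there would compare. Also open, going by these compounds, is whether the same exchange carries over to the core of compound 2, which has hydrogen in place of the methoxy.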